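A sulfur enters the group on compound 2

A few compounds are considered here, and "the series" means these few. Any claim that something is new, unique, unknown or untested is made for them only; others in the source may bear on it.

Of the compounds shown here, three have been measured so far in a physicochemical assay for lipophilicity; a higher number here means a more lipophilic compound, a lower number a more polar compound. Compound 1 `OC(c1ccccc1)c1c(C(F)(F)F)nc2ccc(Br)cc2c1Br` gives 6.26, compound 2 `COc1cccc(NC(=O)Nc2ccc3nc(Oc4ccc(F)cc4C(C)O)c(Cc4ccccc4)cc3c2)c1` gives 6.72, and compound 3 `CC(c1cc(F)ccc1Oc1nc2ccc(-n3cc(-c4ccccc4)nn3)cc2cc1Cc1ccccc1)n1ccnc1` gives 7.91. Compound 2 therefore stands in the middle, higher than compound 1 and lower than compound 3, with both gaps beyond the usual scatter.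

Compound 4 `COc1ccc(NC(=S)Nc2ccc3nc(Oc4ccc(F)cc4C(C)O)c(Cc4ccccc4)cc3c2)cc1` has not yet been measured. It differs from compound 2 in one place, on a nitrogen on an aromatic ring: a group of 11 heavy atoms (8 carbon, 1 nitrogen, 1 oxygen, 1 sulfur; one six-membered aromatic ring of carbon only) in place of a group of 11 heavy atoms (8 carbon, 1 nitrogen, 2 oxygen; one six-membered aromatic ring of carbon only), on a nitrogen on an aromatic ring. The incoming group carries sulfur, which the departing (3-methoxyphenyl)carbamoyl group does not.

Going by the values given here, no measured pair here shows a change of this kind, so the expectation rests on the structural change alone. A small upward move in this assay seems most likely, close to the usual scatter, and no change at all cannot be ruled out. The expected move is a number 0.28 log units higher from compound 2 to compound 4 (within the scatter). Compound 4 is estimated at 7, with an expected range from 6.5 to 7.5.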

Compound 4, partition coefficient: 7.86
Estimate against measurement, compound 4: 0.86 log units below; the measured number lies above the stated range.
By their numbers in this assay, from the lowest: compound 1; then compound 2; then compounds 4 and 3 (each within the scatter of the next).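

Exchanging the (3-methoxyphenyl)carbamoyl group for the sulfur-bearing group, on a nitrogen on an aromatic ring, gives in this assay a number 1.14 log units higher from compound 2 to compound 4 (beyond the scatter). The two groups have the same count of heavy atoms, the same ring, and the same counts of hydrogen-bond donors and acceptors, with sulfur in place of one oxygen, so a large move at this position can come with very little change in those counts. No measurement shown gives a reason for this step.

The compounds shown do not separate the contribution of the sulfur from any other difference between the two groups. On these data alone, whether a similar step would appear with a different group on that nitrogen, such as an acetyl group or a chain ending in a carboxylic acid, also stays open.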